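A few compounds are considered here, and "the series" means these few. Any claim that something is new, unique, unknown or untested is made for them only; others in the source may bear on it.

Of the compounds shown here, three sharing one core have been measured in a functional assay on MCF7 cells (Homo sapiens) for cytotoxicity, read by MTT assay, with a stated time of 72 h; on this read-out lower numbers stand for stronger inhibition and higher numbers for weaker inhibition. In this assay, compound 3 `N[C@H]1CC[C@H](Nc2c(C(=O)NCc3ccc(F)cc3)nc(Br)c3cccnc23)CC1` gives 2000 nM. Compound 2 `Nc1ccc(Nc2c(C(=O)NCc3ccc(F)cc3)nc(Br)c3cccnc23)cc1` gives 4000 nM, and the two are not separated, with a 2.0-fold lower number from compound 2 to compound 3 (0.30 log units; within the scatter). Compound 1 `N[C@H]1CC[C@H](Nc2c(C(=O)NCc3ccc(F)cc3)nc(N3CCCCS3(=O)=O)c3cccnc23)CC1` gives 13000 nM and stands clearly apart, with a 6.5-fold lower number from compound 1 to compound 3 (0.81 log units; beyond the scatter).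

Compound 4 `N[C@H]1CC[C@H](Nc2c(C(=O)NCc3ccc(F)cc3)nc(N3CCCCC3)c3cccnc23)CC1` has piperidin-1-yl in place of bromo on an aromatic carbon, para to the (4-aminocyclohexyl)amino group: piperidin-1-yl in place of bromo on an aromatic carbon. The step to compound 2 concerns another part of the molecule and offers little guidance here. The relevant precedent is compound 1, which carries a six-membered non-aromatic ring at this same carbon, and its step is a 6.5-fold lower number from compound 1 to compound 3 (0.81 log units; beyond the scatter). That ring is not piperidin-1-yl, so the precedent is only partial. A modest rise in this assay is therefore expected, somewhat smaller than that precedent and with real uncertainty about whether it clears the scatter. The expected change is a 3.0-fold higher number from compound 3 to compound 4 (0.48 log units; beyond the scatter). For compound 4 the estimated value is 6000 nM, with an expected range from 2000 nM to 18000 nM.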

Compound 4, half-maximal inhibitory concentration: 5000 nM
Beside the measured number, compound 4's estimate is 1.2-fold (0.08 log units) above it; the range from low to high includes it.
By their numbers in this assay, from the lowest: compounds 3, 2 and 4 (each within the scatter of the next, the first and the last beyond it); then compound 1.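

Replacing bromo with piperidin-1-yl on this aromatic carbon gives a 2.5-fold higher number from compound 3 to compound 4 (0.40 log units; beyond the scatter) in this assay, so a second six-membered non-aromatic ring at this position also gives a higher number than bromo, here one without the sulfur and its two oxygens. The two rings are also separated from each other, with a 2.6-fold lower number from compound 1 to compound 4 (0.41 log units; beyond the scatter), which shows that the make-up of the ring at this carbon counts and not only the presence of a ring. Nothing measured here accounts for either step.

As far as these compounds go, it remains open whether any group at this carbon would give a lower number than bromo, and how a morpholin-4-yl ring or an open-chain dimethylamino group would compare with piperidin-1-yl. The 4-aminophenyl group is also shown only with bromo, so its pairing with piperidin-1-yl remains open.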